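Working notes: isopropyl to isobutyl on a carbonyl carbon

A few compounds are considered here, and "the series" means these few. Any claim that something is new, unique, unknown or untested is made for them only; others in the source may bear on it.

- Compound 1 `CCCCN1CC(CC(=O)NO)(NS(=O)(=O)c2ccc(OCc3cc(C)nc4ccccc34)cc2)C1` gives 70000 nM
- Compound 2 `Cc1cc(COc2ccc(S(=O)(=O)N(C)C3(C(=O)NO)CN(C(=O)C(C)C)C3)cc2)c2ccccc2n1` gives 84000 nM

In a physicochemical assay for solubility, read by HPLC, in phosphate buffer, with a stated time of 24 h, at 20 degrees C, at pH 7.4 (on this read-out lower numbers stand for lower solubility and higher numbers for higher solubility), compound 2 gives 84000 nM, which lies within the scatter of compound 1 at 70000 nM. Compound 3 `Cc1cc(COc2ccc(S(=O)(=O)N(C)C3(C(=O)NO)CN(C(=O)CC(C)C)C3)cc2)c2ccccc2n1` differs from compound 2 in one place, with isobutyl in place of isopropyl on a carbonyl carbon. Going by the values given here, no measured pair shows this change. A small downward step is expected in this assay, perhaps none beyond the scatter, and the expectation starts from compound 2 at 84000 nM. The estimated change is a 1.4-fold lower number from compound 2 to compound 3 (0.15 log units; within the scatter). For compound 3 the estimated value is 60000 nM, with an expected range of 25000 nM to 120000 nM.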

Compound 3, solubility: 62000 nM
The estimate for compound 3 lay 1.0-fold (0.01 log units) below the measured number; measured number inside the range.
By their numbers in this assay, from the lowest: compounds 3, 1 and 2 (each within the scatter of the next).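

In this assay, going by these compounds alone, isobutyl in place of isopropyl on a carbonyl carbon gives a 1.4-fold lower number from compound 2 to compound 3 (0.13 log units; within the scatter), the first single-place step. On a carbonyl carbon whose other neighbours are amide-type nitrogen in a ring, this change therefore stays within the scatter. No measured evidence bears on the reason for this result.

Only these two small alkyl groups have been compared at this position. On these data alone, whether a longer chain, a phenyl ring or a carboxylic acid there would give a step beyond the scatter remains open.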